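Swapping iodo for fluoro on the fused ring of compound 2

The source may report more compounds than this note shows. Statements on the series, on what has been measured and on what is new or still open speak of the compounds shown alone.

Measured so far:
- compound 1, `O=C(O)/C(S)=C/c1c[nH]c2cccc(F)c12`: 10 nM
- compound 2, `O=C(O)/C(S)=C/c1c[nH]c2ccc(I)cc12`: 100 nM
- compound 3, `O=C(O)/C(S)=C/c1ccc(Br)cc1`: 1500 nM

All three were tested in an assay on isolated protein for inhibition of Calpain-1 catalytic subunit (Sus scrofa), read by FRET; on this read-out higher numbers stand for weaker inhibition and lower numbers for stronger inhibition. Compound 2 gives the second highest of the three numbers: compound 1 gives a clearly lower number, and compound 3 a clearly higher one, both gaps beyond the scatter.

Compound 4, `O=C(O)/C(S)=C/c1c[nH]c2ccc(F)cc12`, has not been measured. It differs from compound 2 in one place: fluoro in place of iodo on an aromatic carbon. Among the measured compounds shown here, no measured pair shows this exact change, and the fluoro of compound 1 sits at a different place on the shared core, so its value is only a loose guide. A small step is expected from compound 2 to compound 4 in this assay, a 1.7-fold lower number from compound 2 to compound 4 (0.22 log units; within the scatter), likely not beyond the scatter. Compound 4 is estimated at 60 nM, within 15 nM to 250 nM.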

Compound 4, half-maximal inhibitory concentration: 800 nM
Beside the measured number, compound 4's estimate is 13-fold (1.12 log units) below it; measured number above the stated range.
By their numbers in this assay, from the lowest: compound 1; then compound 2; then compounds 4 and 3 (each within the scatter of the next).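

Among the compounds shown here, this is the first pair in the set that differs in one place, and it shows that the halogen on this aromatic carbon matters: in this assay, fluoro in place of iodo gives an 8.0-fold higher number from compound 2 to compound 4 (0.90 log units; beyond the scatter). Iodo and fluoro are therefore not interchangeable at this position, and inhibition is weaker with fluoro. Nothing available explains why the step has this size.

Going by these compounds, how chloro, methoxy or an amine on this carbon would read remains open. So does whether iodo and fluoro keep this order at the place that carries fluoro in compound 1.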